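Trimethoxyphenyl Replaces Biphenyl at the Ketone

A few compounds are considered here, and "the series" means these few. Any claim that something is new, unique, unknown or untested is made for them only; others in the source may bear on it.

Of the compounds shown here, three sharing one core have been tested in a functional assay on PC-3 cells (Homo sapiens) for cytotoxicity, read by MTT assay, with a stated time of 48 h; a lower number here means a stronger inhibitor, a higher number a weaker inhibitor. Compound 1 `COc1cc(-c2nnc3n2NC(c2cccs2)C(C(=O)c2ccccc2)S3)cc(OC)c1OC` gives 86300 nM. Compound 2 `COc1ccc(C(=O)C2Sc3nnc(-c4cc(OC)c(OC)c(OC)c4)n3NC2c2ccco2)cc1` reaches only a limit of the assay, > 100000 nM. Compound 3 `COc1cc(-c2nnc3n2NC(c2ccco2)C(C(=O)c2ccc(-c4ccccc4)cc2)S3)cc(OC)c1OC` gives 45900 nM, a number that lies within the usual scatter of the value of compound 1, so the two cannot be told apart. One measured step between neighbours exists: an at least 2.1-fold lower number from compound 2 to compound 3 (0.33 log units; beyond the scatter). Compound 4 `COc1cc(C(=O)C2Sc3nnc(-c4cc(OC)c(OC)c(OC)c4)n3NC2c2ccco2)cc(OC)c1OC` has not yet been measured. It differs from compound 3 in one place: 3,4,5-trimethoxyphenyl in place of 4-phenylphenyl on a carbonyl carbon. Going by the values given here, the single measured step bears on this change in reverse, since compound 3 carried a phenyl where compound 2 carried a methoxy, and compound 4 now loses the phenyl and carries methoxy groups instead. That step was at least modest, so a step of similar size in the opposite direction, toward a higher number, is expected here. Compound 4 is therefore expected to give about 90000 nM, with a likely range from 40000 nM to 200000 nM. The expected step is a 2.0-fold higher number from compound 3 to compound 4 (0.29 log units; within the scatter), and the assay may again report only a limit.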

Compound 4, half-maximal inhibitory concentration: 52200 nM
The estimate for compound 4 lay 1.7-fold (0.24 log units) above the measured number; measured number inside the range.
By their numbers in this assay, from the lowest: compounds 3, 4 and 1 (each within the scatter of the next). At a limit, above all of these: compound 2.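

In this assay, swapping 4-phenylphenyl for 3,4,5-trimethoxyphenyl on the carbonyl carbon leaves no readable difference: a 1.1-fold higher number from compound 3 to compound 4 (0.06 log units; within the scatter). So for this pair, the second aromatic ring of 4-phenylphenyl is not needed to reach a number of this size, and a group with one such ring and three methoxy groups serves as well; compared with 4-methoxyphenyl, the same position gives an at least 1.9-fold lower number from compound 2 to compound 4 (0.28 log units; that floor lies within the scatter). That size is only a floor, and the true gap cannot be read, because compound 2 stands at a limit of the assay: the limit of > 100000 nM in this assay, at which 1 of the 4 values shown sits.

Going by these compounds, what remains open is whether this position needs an aromatic ring at all, since a plain ethyl chain or a cyclohexyl group would test that. A group carrying an amine or a carboxylic acid on the ring is equally untested here.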